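The compounds below may be only part of what the source reports. "The series", "measured", "known", "first", "only" and "open" are said of these compounds alone.

Compound 1, `CN(Cc1ccccc1F)C(=O)C1CCN(C(=O)c2ccc(S(C)(=O)=O)c([N+](=O)[O-])c2)CC1`, was examined in an assay on isolated protein for inhibition of vitamin D3 receptor (Homo sapiens), read by fluorescence polarization; a higher number here means a weaker inhibitor, a lower number a stronger inhibitor. In this assay compound 1 gives only a limit of the assay, > 60000 nM, and no finite number. A second compound, compound 2, `CS(=O)(=O)c1ccc(C(=O)N2CCC(C(=O)N3CCC(c4ccccc4)CC3)CC2)cc1[N+](=O)[O-]`, shares the same core but carries a different amide on the piperidine. In this assay compound 2 likewise gives only a limit, > 60000 nM. Within the data shown here, both values thus sit at the same boundary, (the limit of > 60000 nM in this assay, at which 2 of the 2 values shown sit), so no measured step between any pair of compounds exists, and no direction of change can be read from them.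

Compound 3, `CC(C)N(C(=O)C1CCN(C(=O)c2ccc(S(C)(=O)=O)c([N+](=O)[O-])c2)CC1)C(C)C`, differs from compound 1 in one place: diisopropylamino in place of (2-fluorobenzyl)(methyl)amino on a carbonyl carbon. Among the measured compounds shown here, with no measured step to lean on, and with compound 1 already at the limit, no shift beyond the scatter of this assay is expected in either direction. Compound 3 is accordingly expected to give about 80000 nM, with a range from 20000 nM to 300000 nM, and most likely once more only a limit. The step expected from compound 1 to compound 3 is a step that the limit leaves unreadable from compound 1 to compound 3.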

Compound 3, half-maximal inhibitory concentration: > 60000 nM
Compound 3 gave a limit, no number; the forecaster's own chance of this, stated with the estimate: 85%; the middle value does not contradict the limit.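

Compound 3, like compound 1, gives only a limit and no finite number in this assay, so the step between compound 1 and compound 3 cannot be read: the limit of > 60000 nM in this assay, at which 3 of the 3 values shown sit. The compounds shown leave open whether any group on that carbonyl carbon would give a finite value in this assay.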